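What a 4-bromophenyl group may do to inhibition

The source may hold more compounds than are shown below. What is called first, only, known or untested is meant among the compounds shown, and "the series" means these compounds.

In a functional assay on HeLa cells (Homo sapiens) for inhibition, read by MTT assay, with a stated time of 72 h (on this read-out lower numbers stand for stronger inhibition and higher numbers for weaker inhibition), compound 1 (`COc1cc(OC)c(OC)cc1/C=C/C(=O)c1ccc(Cl)cc1`) gives 36500 nM and compound 2 (`COc1cc(OC)c(OC)cc1/C=C/C(=O)c1ccc(O)cc1O`) gives 37600 nM on the same core, so the two stand level (a 1.0-fold higher number from compound 1 to compound 2 (0.01 log units; within the scatter)). Compound 3 (`COc1cc(OC)c(OC)cc1/C=C/C(=O)c1cc(Cl)ccc1O`) gives only a limit of the assay, not a number (> 150000 nM). Its place at the top of the scale shows in two steps, (an at least 4.1-fold higher number from compound 1 to compound 3 (0.61 log units; beyond the scatter)) and (an at least 3.9-fold higher number from compound 2 to compound 3 (0.60 log units; beyond the scatter)), both beyond the scatter.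

Compound 4 (`COc1cc(OC)c(OC)cc1/C=C/C(=O)c1ccc(Br)cc1`) has not been measured. It carries 4-bromophenyl in place of 5-chloro-2-hydroxyphenyl on a carbonyl carbon, so the hydrogen-bond donor of the leaving group goes with it. The step that bears most directly is the one that took 4-chlorophenyl to 5-chloro-2-hydroxyphenyl (an at least 4.1-fold higher number from compound 1 to compound 3 (0.61 log units; beyond the scatter)). Compound 4 makes the same kind of exchange in reverse, with bromine in the group that enters, so a value near that of compound 1 (36500 nM) seems the best guide. The size of the change is uncertain, as compound 3 has no exact number to start from.

In this assay the expected step is towards a lower number (an at least 4.1-fold lower number from compound 3 to compound 4 (0.61 log units; beyond the scatter)). Compound 4 is estimated at 36000 nM as a middle value, with an expected range from 15000 nM to 90000 nM around it.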

Compound 4, half-maximal inhibitory concentration: 31700 nM
Compound 4: middle estimate off by 1.1-fold (0.06 log units), on the high side; measured number inside the range.
By their numbers in this assay, from the lowest: compounds 4, 1 and 2 (each within the scatter of the next). At a limit, above all of these: compound 3.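

In this assay, bromo in place of chloro on an aromatic carbon leaves the result level (a 1.2-fold lower number from compound 1 to compound 4 (0.06 log units; within the scatter)), so at this place the two halogens cannot be told apart. The 4-bromophenyl group also stands level with 2,4-dihydroxyphenyl (a 1.2-fold lower number from compound 2 to compound 4 (0.07 log units; within the scatter)), which puts three different groups on the carbonyl carbon together and leaves 5-chloro-2-hydroxyphenyl as the only one apart from them. Exchanging that group for 4-bromophenyl gives a clear step (an at least 4.7-fold lower number from compound 3 to compound 4 (0.67 log units; beyond the scatter)), but its size is only a lower bound, because the value for compound 3 is a limit of the assay and not a number: the limit of > 150000 nM in this assay, at which 1 of the 4 values shown sits.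

As far as these compounds go, what remains open is which part of 5-chloro-2-hydroxyphenyl goes with the weaker inhibition, a question that a plain 2-hydroxyphenyl group, carrying no chlorine, could help to separate. From the compounds shown here alone, how this place responds to quite different groups also remains unknown, for example a 4-aminophenyl group or a phenyl ring carrying a carboxylic acid.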